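The compounds below may be only part of what the source reports. "The series", "measured", "known", "first", "only" and "open" are said of these compounds alone.

Two compounds have been measured in an assay on HEK293 cells for displacement of a labelled ligand from 5-hydroxytryptamine receptor 6 (Homo sapiens); on this read-out lower numbers stand for stronger inhibition and higher numbers for weaker inhibition:
compound 1 `O=[N+]([O-])c1ccc(N2CCNCC2)cc1NCc1ccccc1`, 28 nM
compound 2 `Cc1cc(C)n(-c2cc(N3CCNCC3)ccc2[N+](=O)[O-])n1`, 482 nM

Compound 1 gives the lowest number of the two, and compound 2, its nearest neighbour, lies beyond the scatter above it. No pair among these compounds differs in only one place, so no single step can be read from the measured values. Compound 3 `O=[N+]([O-])c1ccc(N2CCNCC2)cc1NCc1ccc(Cl)cc1` has not yet been measured in this assay. It differs from compound 1 by chloro in place of hydrogen on an aromatic carbon, sitting on an aromatic carbon of a six-membered aromatic ring of carbon only, para to a large group; cut one bond further out, the change reads benzyl to 4-chlorobenzyl. Among the compounds with values here, nothing among the measured compounds shows how such a change behaves. The step of a 1.4-fold lower number from compound 1 to compound 3 (0.15 log units; within the scatter) is therefore expected to stay within the usual scatter, leaning if anything toward a lower number. Compound 3 is estimated at 20 nM, between 7 nM and 70 nM.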

Compound 3, inhibition constant: 8 nM
Beside the measured number, compound 3's estimate is 2.5-fold (0.40 log units) above it, within the range that was stated.
By their numbers in this assay, from the lowest: compound 3; then compound 1; then compound 2.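

Within the data shown here, this is the first step that can be read at a single place. In this assay, going from benzyl to 4-chlorobenzyl gives a 3.5-fold lower number from compound 1 to compound 3 (0.54 log units; beyond the scatter), so the number moves beyond the usual scatter when chloro replaces hydrogen on this aromatic carbon, para to a large group. The position therefore accepts a chlorine atom without any loss of inhibition, and the read-out responds to a change made there, though the step is modest. Nothing available accounts for this shift.

The compounds shown leave open whether the lower number is particular to chloro or would also appear with fluoro, bromo, methyl or methoxy in the same place. They also rest on this single step, so they do not show whether chloro elsewhere on the ring, or on another core, would act in the same way.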